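A few compounds are considered here, and "the series" means these few. Any claim that something is new, unique, unknown or untested is made for them only; others in the source may bear on it.

Measured compounds in a functional assay on HeLa cells (Homo sapiens) for antiproliferative activity, read by MTT assay, with a stated time of 48 h; a higher number here means a weaker inhibitor, a lower number a stronger inhibitor: compound 1 `COc1ccc(-c2cn3cc(C4=CCN(C(=O)c5ccccc5)CC4)ccc3n2)cc1OC` gives 10200 nM; compound 2 `COc1ccc(-c2cn3cc(C4=CCN(S(=O)(=O)C5CCCC5)CC4)ccc3n2)cc1OC` gives 6470 nM.

Compound 2 stands beside compound 1 in this assay, separated only by a 1.6-fold lower number from compound 1 to compound 2 (0.20 log units; within the scatter), which does not tell the two apart. Compound 3 `COc1ccc(-c2cn3cc(C4=CCN(C(=O)c5cccs5)CC4)ccc3n2)cc1OC` differs from compound 2 by (thiophen-2-yl)carbonyl in place of cyclopentylsulfonyl on an amine nitrogen in a ring. Among the compounds with values here, the one measured step that bears on this, a 1.6-fold lower number from compound 1 to compound 2 (0.20 log units; within the scatter), exchanged a benzoyl for the cyclopentylsulfonyl and stayed within the scatter; compound 3 returns to a carbonyl-linked ring as in compound 1. No step beyond the scatter is therefore expected, a 1.2-fold higher number from compound 2 to compound 3 (0.09 log units; within the scatter). Compound 3 is estimated at 8000 nM, range 3000 nM to 22000 nM.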

Compound 3, half-maximal inhibitory concentration: 16000 nM
Compound 3: the middle estimate sits 2.0-fold (0.30 log units) below what was measured; the range from low to high includes it.
By their numbers in this assay, from the lowest: compounds 2, 1 and 3 (each within the scatter of the next, the first and the last beyond it).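

In this assay, within the data shown here, the group on the ring amine nitrogen now gives a first step beyond the scatter, though a modest one: a 2.5-fold higher number from compound 2 to compound 3 (0.39 log units; beyond the scatter). Exchanging only the ring on the carbonyl carbon does not separate the compounds, with a 1.6-fold higher number from compound 1 to compound 3 (0.20 log units; within the scatter), so thiophen-2-yl and phenyl cannot be told apart here. No evidence available here accounts for the larger step. From the compounds shown here alone, it remains open whether the sulfonyl or its cyclopentyl ring carries that step; phenylsulfonyl and cyclopentylcarbonyl groups on the same nitrogen would separate the two.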